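The source may report more compounds than this note shows. Statements on the series, on what has been measured and on what is new or still open speak of the compounds shown alone.

Measured in a functional assay on HT-29 cells (Homo sapiens) for inhibition, read by luminescence and CellTiter-Glo, with a stated time of 24 h; a higher number here means that more compound is needed for the effect, a lower number that less compound is needed:
compound 1 `CN1C(=S)[C@@H](NC(=O)c2nc(Cc3ccccc3)n(C)n2)COc2ccccc21`: 2.5 nM
compound 2 `CCn1nc(C(=O)N[C@H]2COc3ccccc3N(C)C2=S)nc1Cc1ccccc1`: 17 nM
compound 3 `CN1C(=S)[C@@H](NC(=O)c2nc(Cc3ccccc3)n(C3CCCCC3)n2)COc2ccccc21`: 4000 nM

Compound 3 has the highest number of the three. Compound 4 `CN1C(=S)[C@@H](NC(=O)c2nc(Cc3ccccc3)n(C3CCOCC3)n2)COc2ccccc21` differs from it on an aromatic nitrogen: oxan-4-yl in place of cyclohexyl on an aromatic nitrogen. For the measured compounds named here, three measured steps concern that same group: a 6.8-fold higher number from compound 1 to compound 2 (0.83 log units; beyond the scatter) is modest, while a 1600-fold higher number from compound 1 to compound 3 (3.20 log units; beyond the scatter) and a 240-fold higher number from compound 2 to compound 3 (2.37 log units; beyond the scatter) are large. None of them replaces a ring carbon with oxygen, so they give no direct size for this change. Both groups are six-membered non-aromatic rings, so only a modest step to a lower number is expected in this assay, a 2.7-fold lower number from compound 3 to compound 4 (0.43 log units; beyond the scatter). For compound 4 the estimated value is 1500 nM, with an expected range from 300 nM to 6000 nM.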

Compound 4, half-maximal effective concentration: 2260 nM
Compound 4: middle estimate off by 1.5-fold (0.18 log units), on the low side; the range from low to high includes it.
By their numbers in this assay, from the lowest: compound 1; then compound 2; then compounds 4 and 3 (each within the scatter of the next).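

Oxan-4-yl in place of cyclohexyl gives a 1.8-fold lower number from compound 3 to compound 4 (0.25 log units; within the scatter) in this assay and so the ring oxygen, with its one hydrogen-bond acceptor, does not separate these two compounds. Against the smaller groups the step stays large, with a 130-fold higher number from compound 2 to compound 4 (2.12 log units; beyond the scatter) for ethyl and a 900-fold higher number from compound 1 to compound 4 (2.96 log units; beyond the scatter) for methyl as the group replaced, so a large step does not depend on the ring being carbon only. No measured evidence bears on the reason for this.

Still open, going by these compounds, is how the number changes between ethyl and the six-membered rings, for example with cyclopropyl on this aromatic nitrogen. On these data alone, whether a ring amine such as piperidin-4-yl would match oxan-4-yl also remains open.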